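Chain Length and Tolerated Concentration in a Cell Assay

The compounds below may be only part of what the source reports. "The series", "measured", "known", "first", "only" and "open" are said of these compounds alone.

Measured compounds:
Compound 1 `CCCCCCCC#Cc1cc2cn(COCCO)c(=O)nc2o1`: > 50000 nM
Compound 2 `CCCCCCCCC#Cc1cc2cn(COCCO)c(=O)nc2o1`: 42000 nM
Compound 3 `CCCCCc1cc2cn(COCCO)c(=O)nc2o1`: > 200000 nM

All three share one core and differ only in the side chain that hangs from it. They were tested in a functional assay on HEL cells (Homo sapiens); a higher number here means that more compound is tolerated, a lower number that less compound is tolerated. Compound 1 gives only a limit there, > 50000 nM. Compound 3 likewise gives only a limit, > 200000 nM. Within the data shown here, compound 2 is the one compound with a full number, 42000 nM.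

Compound 2 differs from compound 1 by methyl in place of hydrogen on a saturated chain carbon, seven bonds along the chain from a triple-bonded carbon. This gave an at least 1.1-fold lower number from compound 1 to compound 2 (0.07 log units; that floor lies within the scatter). That step is only a floor because the limit of > 50000 nM in this assay, at which 1 of the 3 values shown sits, is where compound 1 sits, so the true size of the step is not known. How the cores of compound 1 and compound 3 differ is not broken down here.

Compound 4 `CCCCCCc1cc2cn(COCCO)c(=O)nc2o1` has not yet been measured. It differs from compound 3 by methyl in place of hydrogen on a saturated chain carbon, five bonds along the chain from an aromatic carbon. Among the measured compounds shown here, this is the same kind of change as the one from compound 1 to compound 2, but the place is not identical: there the methyl enters seven bonds along the chain from a triple-bonded carbon, here five bonds along the chain from an aromatic carbon. The earlier step stayed within the scatter, so a small step is expected here too, giving an expected a number no higher from compound 3 to compound 4 (the limit leaves the size open). That expectation rests on an at least 1.1-fold lower number from compound 1 to compound 2 (0.07 log units; that floor lies within the scatter) and on compound 3 sitting at the limit of > 200000 nM in this assay, at which 1 of the 3 values shown sits. Compound 4 is therefore estimated at 200000 nM, with a range from 80000 nM to 400000 nM, and most likely it will again be reported only as a limit.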

Compound 4, half-maximal cytotoxic concentration: > 200000 nM
Compound 4: no number, only a limit (the forecaster's own chance of this, stated with the estimate: 70%); the middle value sits exactly at the limit.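

Among these compounds, compound 3 and compound 4 each give only a limit in this assay, so no step between them can be read: the limit of > 200000 nM in this assay, at which 2 of the 4 values shown sit. The compounds shown leave open how far the true numbers of compound 3 and compound 4 lie past that limit, and so whether methyl in place of hydrogen at this place changes the tolerated concentration at all.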